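The source may report more compounds than this note shows. Statements on the series, on what has been measured and on what is new or still open speak of the compounds shown alone.

Measured compounds:
- compound 1, `C=CCNC(=O)/C(C)=C(/C)c1ccccc1`, 400 mg/kg in a toxicity assay on the whole organism (strain Icem-CET (SPF Caw)) for cytotoxicity, with Mus musculus as the target; a lower number here means that less compound is needed, a higher number that more compound is needed for the effect
- compound 2, `C/C(C(=O)NC1CC1)=C(\C)c1ccccc1`, 300 mg/kg in this assay
- compound 3, `C/C(C(=O)NC1CC1)=C(/C)c1ccc(Cl)cc1`, 150 mg/kg in this assay

Compound 1 and compound 2 share a core and differ only at the amide-type nitrogen, (allyl in place of cyclopropyl on an amide-type nitrogen). Among the measured compounds shown here, the step of a 1.3-fold higher number from compound 2 to compound 1 (0.12 log units; within the scatter) is the one measured instance of this change. Compound 3 carries a different core; the difference between the core of compound 2 and the core of compound 3 is not broken down here. Compound 3 gives the lowest number of the three, yet its step to compound 2 lies within the scatter, so no order between compound 2 and compound 3 is claimed; only its distance to compound 1 lies beyond the scatter.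

Compound 4, `C=CCNC(=O)/C(C)=C(\C)c1ccc(Cl)cc1`, is not yet measured. It differs from compound 3 by allyl in place of cyclopropyl on an amide-type nitrogen, at the same place as the change from compound 2 to compound 1, so this is the same change made on the core of compound 3. For the measured compounds named here, the one measured instance of it, a 1.3-fold higher number from compound 2 to compound 1 (0.12 log units; within the scatter), is within the scatter, so only a small step is expected; whether the change behaves alike on the core of compound 3 cannot be checked from one instance. Compound 4 is expected at 200 mg/kg, within 120 mg/kg and 350 mg/kg, an expected step of a 1.3-fold higher number from compound 3 to compound 4 (0.12 log units; within the scatter) that rests on compound 3 at 150 mg/kg and on the step of a 1.3-fold higher number from compound 2 to compound 1 (0.12 log units; within the scatter).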

Compound 4, dose for half-maximal effect: 70 mg/kg
Estimate against measurement, compound 4: 2.9-fold (0.46 log units) above, and the stated range ends above it.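

In this assay, allyl in place of cyclopropyl on the amide-type nitrogen does not carry over as one fixed step from one core to the other: the same change on two cores in this assay, a 1.3-fold higher number (0.12 log units; within the scatter) from compound 2 to compound 1 and a 2.1-fold lower number (0.33 log units; beyond the scatter) from compound 3 to compound 4, 2.9-fold (0.46 log units) apart, beyond the scatter of two such steps On the core of compound 3 the change gives a 2.1-fold lower number from compound 3 to compound 4 (0.33 log units; beyond the scatter), a modest step, while on the core of compound 2 the step stays within the scatter, so in this series a step read on one core is a poor estimate for the other. This rests on a single pair per core: it shows that the outcome of this change differs between these two cores, but it does not show what in the cores sets that difference, and it gives no rule for any third core or for any other replacement.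

Open, as far as these compounds go, is whether other groups on the amide-type nitrogen, such as a propyl chain, a cyclobutyl ring or a longer chain, would also give different steps on the two cores. Also open, from the compounds shown here alone, is which feature of the cores matters, a question that a compound with fluorine in place of the chlorine on the core of compound 3, carrying cyclopropyl and allyl in turn, could begin to address.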